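The compounds below may be only part of what the source reports. "The series", "measured", "known", "first", "only" and "open" are said of these compounds alone.

Compound 1 `CC1(C)C=C(n2ccccc2=O)c2cc(C(=O)c3ccccc3)ccc2O1`: in a functional assay (trachea) with Rattus norvegicus as the target (on this read-out lower numbers stand for lower potency and higher numbers for higher potency (the scale is a negative logarithm)), compound 1 gives 6.21.
Compound 2 `CC1(C)C=C(n2ccccc2=O)c2cc(C(=O)c3cccs3)ccc2O1`: in this assay compound 2 gives 5.84.

Among the compounds with values here, compound 2 stands at the lower of the two numbers measured so far; its only neighbour is compound 1, and the single measured step, a number 0.37 log units lower from compound 1 to compound 2 (beyond the scatter), lies beyond the scatter. Compound 3 `CC1(C)C=C(n2ccccc2=O)c2cc(C(=O)c3ccc(O)cc3)ccc2O1` has not yet been measured. It differs from compound 2 in one place: 4-hydroxyphenyl in place of thiophen-2-yl on a carbonyl carbon. Within the data shown here, the one step that bears on this change is the step from compound 1 to compound 2, which went from phenyl to thiophen-2-yl and cost a modest amount of potency. Compound 3 returns to a six-membered aromatic ring of carbon only, now carrying a hydroxyl group; nothing measured here shows what that hydroxyl does, and the range is kept wide. The step is expected to recover most of that earlier loss, a number 0.26 log units higher from compound 2 to compound 3 (within the scatter). Compound 3 is therefore estimated at 6.1, between 5.6 and 6.6.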

Compound 3, logarithm of the reciprocal of the active concentration, log(1/C): 5.87
Compound 3: middle estimate off by 0.23 log units, on the high side, within the range that was stated.
By their numbers in this assay, from the lowest: compounds 2 and 3 (each within the scatter of the next); then compound 1.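

Placing 4-hydroxyphenyl on the carbonyl carbon instead of thiophen-2-yl gives a number 0.03 log units higher from compound 2 to compound 3 (within the scatter) in this assay, so this read-out does not separate these two groups at this position. Adding a hydroxy group to the phenyl of compound 1, in place of hydrogen on an aromatic carbon, gives a number 0.34 log units lower from compound 1 to compound 3 (beyond the scatter), which shows that even this single substitution carries a modest cost. Thus, neither change from the phenyl of compound 1 retains its potency in these three compounds. Nothing available explains this loss of potency.

On these data alone, it remains open whether a methoxy group, an amine or a carboxylic acid in place of the hydroxy group would give a similar number. As far as these compounds go, it is also open whether a hydroxy group elsewhere on the phenyl ring would carry the same cost.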